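The source may report more compounds than this note shows. Statements on the series, on what has been measured and on what is new or still open speak of the compounds shown alone.

Measured compounds:
- compound 1, `O=C(C1CCC1)N1CC2CC(C1)N2`, 100%
- compound 2, `O=C([C@H]1C[C@@H]1F)N1CC2CC(C1)N2`, 100%

The two measured compounds share one core and differ only in the group on the carbonyl carbon. In an assay on SH-EP1 cells for agonist activity at Neuronal acetylcholine receptor; alpha4/beta2 (Homo sapiens), read by FLIPR and calcium flux (a lower number here means a smaller maximal response, a higher number a larger maximal response), compound 1 gives 100%, and compound 2 gives 100%. Within the data shown here, the single measured step, no change at the digits printed from compound 1 to compound 2 (within the scatter), therefore shows that swapping the ring on the carbonyl carbon left the maximal response where it was.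

Compound 2 stands level with compound 1 on this read-out, the reference value being reached in both cases.

The next compound, compound 3, is `C[C@@H]1C[C@H]1C(=O)N1CC2CC(C1)N2`. It differs from compound 2 in one place:

2-methylcyclopropyl in place of 2-fluorocyclopropyl on a carbonyl carbon

Among the measured compounds shown here, the only step that bears on this change is the one from compound 1 to compound 2, which kept the response unchanged despite a change of ring on the same carbonyl carbon. On that basis a change of similar size is expected here, namely a number 5 percentage points lower from compound 2 to compound 3 (within the scatter), with no shift beyond the scatter. The estimate for compound 3 in this assay is 95%, within a range of 70% to 105%.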

Compound 3, largest response reached (Emax), in percent of the reference or control that the assay uses: 110%
Estimate against measurement, compound 3: 15 percentage points below; the measured number lies above the stated range.
By their numbers in this assay, from the lowest: compounds 1, 2 and 3 (each within the scatter of the next).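

In this assay, the step of a number 10 percentage points higher from compound 2 to compound 3 (within the scatter) shows that the fluorine of the 2-fluorocyclopropyl group can be exchanged for the carbon of a methyl, giving 2-methylcyclopropyl, without the maximal response moving outside the usual scatter. The step of a number 10 percentage points higher from compound 1 to compound 3 (within the scatter) shows the same for the exchange of cyclobutyl, so the three groups tried on this carbonyl carbon, whose other neighbour is an amide-type nitrogen in a ring, cannot be told apart by this read-out. Nothing measured here offers an explanation for this tolerance.

All three groups are small rings, so the compounds shown leave open whether an open chain such as a longer alkyl chain, or a group carrying an amine or a carboxylic acid, would keep the response at the same level on this carbonyl carbon. They also leave open how much of each compound is needed to reach its response, as only the largest response reached is given here.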